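A few compounds are considered here, and "the series" means these few. Any claim that something is new, unique, unknown or untested is made for them only; others in the source may bear on it.

Of the compounds shown here, three sharing one core have been measured in a functional assay on SK-MEL-5 cells (Homo sapiens) for inhibition, read by sulforhodamine B assay, with a stated time of 48 h; a lower number here means a stronger inhibitor of growth, a higher number a weaker inhibitor of growth. Compound 1, `N=C(N)c1ccc(-c2ccc(-c3cc(Cl)cc(Cl)c3)s2)cc1`, gives 1600 nM. Compound 2, `N=C(N)c1ccc(-c2ccc(-c3ccc(F)cc3)s2)cc1`, gives 1600 nM. Compound 3, `N=C(N)c1ccc(-c2ccc(-c3ccc(Cl)cc3)s2)cc1F`, gives 1270 nM, the lowest of the three numbers, though the gap to compound 1 and the gap to compound 2 both lie within the scatter, so no order among the three can be read from these values.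

The step considered here leads from compound 3 to compound 4, `COc1ccc(-c2ccc(-c3ccc(C(=N)N)c(F)c3)s2)cc1`, which has not yet been measured. The structural change is methoxy in place of chloro on an aromatic carbon. Within the data shown here, no step between two measured compounds that differ only in this way is available, so nothing directly tells how a methoxy in place of a chloro on that aromatic carbon bears on growth inhibition in this assay. The three measured values all fall close together despite differing substituents on the same ring, which suggests that this ring tolerates variation without large shifts.

Compound 4 is therefore expected to stay near the measured values, with the step from compound 3 estimated as a 1.4-fold higher number from compound 3 to compound 4 (0.15 log units; within the scatter), no larger than the scatter in either direction. The estimate for compound 4 is 1800 nM, expected between 700 nM and 4500 nM.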

Compound 4, concentration for 50% growth inhibition: 2670 nM
The estimate for compound 4 lay 1.5-fold (0.17 log units) below the measured number; the range from low to high includes it.
By their numbers in this assay, from the lowest: compounds 3, 1, 2 and 4 (each within the scatter of the next, the first and the last beyond it).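

In this assay, among these compounds, methoxy in place of chloro on the aromatic carbon para to a large group gives a 2.1-fold higher number from compound 3 to compound 4 (0.32 log units; beyond the scatter), the first direct reading of a change at this position, as the earlier compounds offered no pair differing in one place. The step is modest but beyond the scatter, so the close grouping of the earlier values does not mean that this position accepts any group without consequence: here the methoxy, which brings a hydrogen-bond acceptor that chloro lacks, goes with weaker growth inhibition. No measurement at hand accounts for this shift.

The compounds shown leave open whether the step reflects something particular to methoxy, since a single pair cannot show how an amine, a hydroxyl or a longer chain such as ethoxy on the same carbon would compare with chloro. They also leave open whether methoxy in place of chloro gives a step of similar size on a core without the fluoro carried by compound 3 and compound 4.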